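The source may hold more compounds than are shown below. What is called first, only, known or untested is meant among the compounds shown, and "the series" means these compounds.

Within the data shown here, compound 2, whose structure is `CC(C)(Oc1ccc(F)cc1[N+](=O)[O-])C1OCC(C/C=C\CCC(=O)O)C(c2cccnc2)O1`, is one of two compounds measured in an assay for inhibition of prostacyclin synthase (Homo sapiens), using microsomes; on this read-out higher numbers stand for weaker inhibition and lower numbers for stronger inhibition. In this assay compound 2 gives 9000 nM, the lowest of the two numbers. Among the measured compounds shown here, the only other measured compound, compound 1 with structure `CC(C)(Oc1ccccc1)C1OCC(C/C=C\CCC(=O)O)C(c2cccnc2)O1`, gives 75000 nM in this assay, and the step of an 8.3-fold lower number from compound 1 to compound 2 (0.92 log units; beyond the scatter) is beyond the scatter. Compound 3, structure `CC(C)(Cc1ccc(F)cc1)C1OCC(C/C=C\CCC(=O)O)C(c2cccnc2)O1`, has not been measured. It differs from compound 2 by a group of 8 heavy atoms (7 carbon, 1 fluorine; one six-membered aromatic ring of carbon only) in place of a group of 11 heavy atoms (6 carbon, 1 nitrogen, 3 oxygen, 1 fluorine; one six-membered aromatic ring of carbon only), on a saturated chain carbon bound to two saturated chain carbons and a saturated ring carbon. For the measured compounds named here, no measured step matches this change, since the one known step alters only the aryl group and leaves the oxygen in place, while here the oxygen and the nitro group both go. Because compound 1 without those groups gives 75000 nM, a weaker number than compound 2 is expected, and the step of a 3.3-fold higher number from compound 2 to compound 3 (0.52 log units; beyond the scatter) is the estimated size. Compound 3 is expected to give 30000 nM in this assay, within 6000 nM to 150000 nM.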

Compound 3, half-maximal inhibitory concentration: 2000 nM
The estimate for compound 3 lay 15-fold (1.18 log units) above the measured number; the measured number lies below the stated range.
By their numbers in this assay, from the lowest: compound 3; then compound 2; then compound 1.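

In this assay, 4-fluorobenzyl on this saturated chain carbon replaces the larger nitro-bearing group with a 4.5-fold lower number from compound 2 to compound 3 (0.65 log units; beyond the scatter) and replaces phenoxy with a 38-fold lower number from compound 1 to compound 3 (1.57 log units; beyond the scatter) as the result, so neither the ether oxygen nor a nitro group is needed for the lowest number among these compounds. Among these compounds, the earlier step showed only that changing the aryl group could lower the number, whereas these steps show that the atom joining that ring to the chain carbon can change too, although fluorine is also added from compound 1 to compound 3 and the two contributions cannot be separated. Nothing measured here gives a reason for these differences.

How much of the gain comes from the fluorine remains open, since a plain benzyl group is not among these compounds. Also open, from the compounds shown here alone, is how a longer chain, such as 2-phenylethyl, or an amine joining the ring to this carbon would compare.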